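Swapping benzoxazole for benzothiazole in compound 1

This account rests on a few compounds, and the source may have more. Where it says the series, first, only, none or still open, it means among the compounds named here.

Measured in a functional assay on HeLa cells (Homo sapiens) for antiproliferative activity, read by MTT assay, with a stated time of 48 h; on this read-out lower numbers stand for stronger inhibition and higher numbers for weaker inhibition:
compound 1 `CN(C)CCCCn1c(N)c(-c2nc3ccccc3o2)c2nc(C#N)c(C#N)nc21` gives 1950 nM
compound 2 `CCN(CC)CCCCn1c(N)c(-c2nc3ccccc3o2)c2nc(C#N)c(C#N)nc21` gives 6420 nM

Compound 1 holds the lower of the two numbers, so it is the stronger inhibitor of this pair. Compound 3 `CN(C)CCCCn1c(N)c(-c2nc3ccccc3s2)c2nc(C#N)c(C#N)nc21` keeps the core of compound 1 and its 4-(dimethylamino)butyl group, but carries 1,3-benzothiazol-2-yl in place of 1,3-benzoxazol-2-yl on an aromatic carbon. The two groups differ only in oxygen against sulfur. Going by the values given here, no measured step touches this place. Among the compounds with values here, the one available step, a 3.3-fold higher number from compound 1 to compound 2 (0.52 log units; beyond the scatter), comes from a change on the chain and gives only a rough idea of what a single change can do here. In this assay no step beyond the scatter is expected, an estimated 1.0-fold higher number from compound 1 to compound 3 (0.01 log units; within the scatter) with neither direction favoured. In this assay compound 3 is expected at 2000 nM (expected range 700 nM to 6000 nM).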

Compound 3, half-maximal inhibitory concentration: 18700 nM
Beside the measured number, compound 3's estimate is 9.4-fold (0.97 log units) below it; the whole stated range lies below it.
By their numbers in this assay, from the lowest: compound 1; then compound 2; then compound 3.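

In this assay, the aromatic carbon carrying this ring group proves sensitive: putting sulfur in place of the ring oxygen, turning 1,3-benzoxazol-2-yl into 1,3-benzothiazol-2-yl, gives a 9.6-fold higher number from compound 1 to compound 3 (0.98 log units; beyond the scatter). The earlier pair showed only that the chain could move the number, whereas this result shows that a swap leaving the heavy-atom count, ring types and hydrogen-bond donor and acceptor counts unchanged can also carry it beyond the scatter, and compound 1 remains the strongest inhibitor of the three. Nothing available explains this difference.

Going by these compounds, whether the loss is specific to sulfur remains open, since a 1H-benzimidazol-2-yl group, with a ring nitrogen bearing hydrogen in that place, could land near either compound. Also open, on these data alone, is how 1,3-benzothiazol-2-yl would behave alongside a diethylamino chain end.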